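The source may report more compounds than this note shows. Statements on the series, on what has been measured and on what is new or still open speak of the compounds shown alone.

Compounds measured in a functional assay on the whole organism (strain Swiss albino) for inhibition, with Mus musculus as the target, read by paw edema, with stated times of 30 min and 180 min, at a dose of 100 mg/kg by the subcutaneous route; a lower number here means less inhibition, a higher number more inhibition at the dose given (going by the name of the read-out):
compound 1 `CCOC(=O)C1CCN(C(=O)c2cc(-c3ccc(C)cc3)nn2Cc2ccccc2)CC1` gives 33.3%
compound 2 `Cc1ccc(-c2cc(C(=O)NCc3cccnc3)n(Cc3ccccc3)n2)cc1` gives 16.5%

Compound 2 stands lowest of the two numbers in this assay; compound 1 sits higher by a gap that is beyond the usual scatter. Compound 3 `Cc1ccc(-c2cc(C(=O)NNc3ccc4ccccc4n3)n(Cc3ccccc3)n2)cc1` has not yet been measured. It differs from compound 2 in a single place: (quinolin-2-yl)amino in place of (pyridin-3-yl)methyl on an amide-type nitrogen. For the measured compounds named here, no measured pair shows what this kind of change does to paw edema inhibition, so the expected step is small, within the scatter, with only a slight rise: a number 5.5 percentage points higher from compound 2 to compound 3 (within the scatter). For compound 3 the estimate in this assay is 22%, with a likely range from 5% to 45%.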

Compound 3, a percentage reported as inhibition, in the whole organism at one dose (the size of the read-out at that dose, not a potency): 24.1%
Beside the measured number, compound 3's estimate is 2.1 percentage points below it, and the stated range covers the measured number.
By their numbers in this assay, from the lowest: compounds 2, 3 and 1 (each within the scatter of the next, the first and the last beyond it).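

On an amide-type nitrogen, (quinolin-2-yl)amino in place of (pyridin-3-yl)methyl gives a number 7.6 percentage points higher from compound 2 to compound 3 (within the scatter) in this assay. So this position can carry the larger group, with its second aromatic ring and its hydrogen-bond donor, without a step beyond the usual scatter. Nothing available explains this result.

From the compounds shown here alone, this single change swaps the ring and the link to the amide-type nitrogen together, so their separate contributions stay unknown. A (pyridin-3-yl)amino group on the same nitrogen would help separate them.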